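The source may hold more compounds than are shown below. What is called first, only, known or untested is meant among the compounds shown, and "the series" means these compounds.

Measured so far in a functional assay on HeLa cells (Homo sapiens) for cytotoxicity, read by MTT assay, with a stated time of 72 h; a higher number here means a weaker inhibitor, a lower number a stronger inhibitor:
- compound 1 `O=C(NCCO)c1cc2ccc(OCc3cccc(Br)c3)cc2oc1=O`: 17600 nM
- compound 2 `CCN(CC)c1ccc2cc(C(=O)NO)c(=O)oc2c1`: 35900 nM
- compound 3 `NNC(=O)c1cc2ccc(OCc3ccc([N+](=O)[O-])cc3)cc2oc1=O`: > 100000 nM

For compound 3 the value in this assay is a limit of the assay, not a number; nothing further is read from it.

Among the two numbers in hand, compound 2 stands highest, the weaker inhibitor. Its nearest neighbour is compound 1, with 17600 nM; the gap between the two lies beyond the usual scatter of the assay. Within the data shown here, no pair of measured compounds differs in a single place, so no measured step is available to calibrate the change that follows.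

The unmeasured compound 4 `CCN(CC)c1ccc2cc(C(=O)N/N=C(/C)c3cccnc3)c(=O)oc2c1` is compared with compound 2. The difference: a group of 9 heavy atoms (7 carbon, 2 nitrogen; one six-membered aromatic ring with 1 hetero atom) in place of one oxygen atom, on an amide-type nitrogen. The hydroxy on the amide-type nitrogen of compound 2 is replaced by the larger group carrying the six-membered aromatic ring with one hetero atom and the double bond outside aromatic rings.

With no measured step of this kind in the series, the expectation for this assay is a step of modest size, as likely down as up, and possibly none beyond the scatter. Compound 4 is accordingly estimated at 30000 nM, within 8000 nM to 100000 nM. The step this estimate implies, a 1.2-fold lower number from compound 2 to compound 4 (0.08 log units; within the scatter), is expected to stay close to the scatter, with a real chance that only a limit is reported.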

Compound 4, half-maximal inhibitory concentration: 70000 nM
Compound 4: the middle estimate sits 2.3-fold (0.37 log units) below what was measured; low and high end bracket the measured number.
By their numbers in this assay, from the lowest: compound 1; then compounds 2 and 4 (each within the scatter of the next). At a limit, above all of these: compound 3.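

Among these compounds, the first measured step at this position, on an amide-type nitrogen whose other neighbour is the carbonyl carbon, comes from this assay: exchanging the hydroxy for the group of 9 heavy atoms gives a 1.9-fold higher number from compound 2 to compound 4 (0.29 log units; within the scatter). A much larger group carrying a six-membered aromatic ring with 1 hetero atom and a double bond outside aromatic rings, with 0 hydrogen-bond donors against 1 for the hydroxy, therefore leaves the read-out within the scatter, and neither the hydroxy nor this group separates from the other here. Little can be read upward from this position, since compound 3, with a related amide-type side chain on a different core, stands at a limit and not a number: the limit of > 100000 nM in this assay, at which 1 of the 4 values shown sits.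

On these data alone, whether a methyl or a longer alkyl chain on this nitrogen, or a plain phenyl ring in place of the ring with 1 hetero atom, would give a step beyond the scatter stays open. Among the compounds shown here, also open is whether the same exchange would behave alike on the core of compound 1, which no single-place pair connects to compound 2 or compound 4.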